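From Cyclohexyl to Cyclopentyl at the Assay Limit

A few compounds are considered here, and "the series" means these few. Any claim that something is new, unique, unknown or untested is made for them only; others in the source may bear on it.

In a functional assay on HCT-15 cells (Homo sapiens) for antiproliferative activity, read by sulforhodamine B assay (on this read-out lower numbers stand for stronger inhibition of growth and higher numbers for weaker inhibition of growth), compound 1 (`O=C(/C=C/c1ccc(O)cc1)c1c(O)cccc1OCCC1CCCCC1`) gives > 30000 nM as a limit of the assay. Compound 2 (`O=C(/C=C/c1ccc(O)cc1)c1c(O)cccc1OCC1CCCCC1`) likewise gives only a limit, > 30000 nM in this assay again. Within the data shown here, the one measured change in this side chain is a step that the two limits leave unreadable from compound 1 to compound 2 and offers no size to carry forward, with both compounds resting on the limit of > 30000 nM in this assay, at which 2 of the 2 values shown sit, alone. Compound 3 (`O=C(/C=C/c1ccc(O)cc1)c1c(O)cccc1OCC1CCCC1`) brings cyclopentyl in place of cyclohexyl on a saturated chain carbon bound to an oxygen on an aromatic ring and nothing else. The estimated step is a number no higher from compound 2 to compound 3 (the limit leaves the size open) in this assay and none beyond the scatter is expected. Compound 3 is expected near 30000 nM within a range of 12000 nM to 60000 nM and may well return only a limit.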

Compound 3, concentration for 50% growth inhibition: 3410 nM
Beside the measured number, compound 3's estimate is 8.8-fold (0.94 log units) above it; the whole stated range lies above it.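

In this assay, this position on a saturated chain carbon bound to an oxygen on an aromatic ring proves able to respond to the group it carries: cyclopentyl in place of cyclohexyl gives an at least 8.7-fold lower number from compound 2 to compound 3 (0.94 log units; beyond the scatter). Cyclopentyl in place of cyclohexylmethyl gives an at least 8.7-fold lower number from compound 1 to compound 3 (0.94 log units; beyond the scatter). Both steps start from a limit, so their full size stays open: the limit of > 30000 nM in this assay, at which 2 of the 3 values shown sit.

The compounds shown leave open whether a cyclobutyl ring or an open isobutyl chain would read like cyclopentyl. They also leave open how an amine on the ring would read.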